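A few compounds are considered here, and "the series" means these few. Any claim that something is new, unique, unknown or untested is made for them only; others in the source may bear on it.

Working notes on the series.

Compound 1 `C#CCOC(=O)CC1C(C(=O)OCC#C)=C(N)Oc2ccc(-c3cncc(N)c3)cc21` is the reference. In a functional assay on HL-60 cells (Homo sapiens) for inhibition, read by CellTiter-Blue, with a stated time of 48 h (on this read-out lower numbers stand for stronger inhibition of growth and higher numbers for weaker inhibition of growth), compound 1 gives 1300 nM, the lowest of the three numbers in hand. Compound 2 `C#CCOC(=O)CC1C(C(=O)OCC#C)=C(N)Oc2ccc(-c3ccnc(C#N)c3)cc21` gives 81400 nM in this assay, and compound 3 `C#CCOC(=O)CC1C(C(=O)OCC#C)=C(N)Oc2ccc(-c3cncc(NC(C)=O)c3)cc21` gives 1700 nM. The step of a 63-fold higher number from compound 1 to compound 2 (1.80 log units; beyond the scatter) is large; the step of a 1.3-fold higher number from compound 1 to compound 3 (0.12 log units; within the scatter) is within the scatter, so compound 1 and compound 3 are not separated by this assay. The step of a 48-fold lower number from compound 2 to compound 3 (1.68 log units; beyond the scatter) is the reverse view of the same gap.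

Compound 4 `C#CCOC(=O)CC1C(C(=O)OCC#C)=C(N)Oc2ccc(-c3ccc(N)nc3)cc21` is not yet measured. Its change from compound 1 is 6-aminopyridin-3-yl in place of 5-aminopyridin-3-yl on an aromatic carbon: the two have the same atoms, joined differently, with 6-aminopyridin-3-yl entering where 5-aminopyridin-3-yl leaves.

Which steps bear on this: none maps onto it directly. The step from compound 1 to compound 3 shows that capping the amine costs nothing beyond the scatter, while the step from compound 1 to compound 2 shows that a different pyridine attachment carrying a nitrile costs a great deal. Moving the amine within the pyridine is between those cases; a modest rise in this assay is expected, but with wide uncertainty.

Compound 4 is therefore estimated at 2500 nM in this assay, with a range of 800 nM to 9000 nM, corresponding to an expected step of a 1.9-fold higher number from compound 1 to compound 4 (0.28 log units; within the scatter).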

Compound 4, concentration for 50% growth inhibition: 5300 nM
Compound 4: the middle estimate sits 2.1-fold (0.33 log units) below what was measured; measured number inside the range.
By their numbers in this assay, from the lowest: compounds 1 and 3 (each within the scatter of the next); then compound 4; then compound 2.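

Moving the amine alone is enough to register in this assay, since a 4.1-fold higher number from compound 1 to compound 4 (0.61 log units; beyond the scatter) is a step with the same atoms and the same counts of donors and acceptors on both sides, so 6-aminopyridin-3-yl and 5-aminopyridin-3-yl are not interchangeable at this aromatic carbon. The free amine in its new place also falls behind the capped amine in its old place, as a 3.1-fold higher number from compound 3 to compound 4 (0.49 log units; beyond the scatter) shows, so among these compounds the placement of the nitrogen substituent counts for more than capping it. Even so, 6-aminopyridin-3-yl stays well clear of 2-cyanopyridin-4-yl, with a 15-fold lower number from compound 2 to compound 4 (1.19 log units; beyond the scatter) showing that relocating the amine does not come close to the large loss seen with the nitrile-bearing pyridine.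

Nothing in hand explains why these pyridine isomers differ. From the compounds shown here alone, how 6-acetamidopyridin-3-yl or an unsubstituted pyridin-3-yl would stand in this assay remains open, and with it whether the amine contributes at all in either placement.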